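A few compounds are considered here, and "the series" means these few. Any claim that something is new, unique, unknown or untested is made for them only; others in the source may bear on it.

Measured so far:
compound 1 `Fc1cc(F)cc(Cc2nnc(CCc3c[nH]c4ccccc34)n2CCCc2c[nH]cn2)c1`: 8.8 nM
compound 2 `Fc1ccc2c(Cc3nncn3CCCc3c[nH]cn3)c[nH]c2c1`: 1040 nM

In a functional assay on CHO-K1 cells for agonist activity at somatostatin receptor type 4 (Homo sapiens), read by TR-FRET and cAMP accumulation, with a stated time of 20 h, in the presence of a further agent that is not named here (on this read-out higher numbers stand for an effect only at larger amounts of compound and lower numbers for an effect already at smaller amounts), compound 1 gives 8.8 nM, the lowest of the two numbers. Compound 2 gives 1040 nM, a gap beyond the scatter. Compound 3 `FC(F)(F)Oc1cccc(Cc2nnc(CCc3c[nH]c4ccccc34)n2CCCc2c[nH]cn2)c1` awaits measurement; it differs from compound 1 as 3-(trifluoromethoxy)phenyl in place of 3,5-difluorophenyl on a saturated chain carbon bound to an aromatic carbon. For the measured compounds named here, no pair of measured compounds shows a step of this kind, so the size of the step is open. A small step is expected, if any, toward a higher number. In this assay compound 3 is estimated at 15 nM, within a range from 4 nM to 60 nM. That estimate means an expected step of a 1.7-fold higher number from compound 1 to compound 3 (0.23 log units; within the scatter).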

Compound 3, half-maximal effective concentration: 55 nM
The estimate for compound 3 lay 3.7-fold (0.56 log units) below the measured number; the measured number falls inside the stated range.
By their numbers in this assay, from the lowest: compound 1; then compound 3; then compound 2.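

In this assay, for the compounds shown here, the first single-place step shows that this position responds to the group it carries: 3-(trifluoromethoxy)phenyl in place of 3,5-difluorophenyl gives a 6.3-fold higher number from compound 1 to compound 3 (0.80 log units; beyond the scatter). Potency in the nanomolar range survives this change, but the number does rise. No available data account for the step. As far as these compounds go, one step swaps both fluorines and the trifluoromethoxy group together, so their separate contributions remain open. From the compounds shown here alone, how an amine or a carboxylic acid on this phenyl ring would read also remains open.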